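The compounds below may be only part of what the source reports. "The series", "measured", "known", "first", "only" and "open" are said of these compounds alone.

Measured in a functional assay on MDA-MB-435 cells (Homo sapiens) for cytotoxicity, read by MTT assay, with a stated time of 72 h; on this read-out lower numbers stand for stronger inhibition and higher numbers for weaker inhibition:
- compound 1 `N[C@H]1CC[C@H](Nc2c(C(=O)NCc3ccc(F)cc3)nc(N3CCCCS3(=O)=O)c3cccnc23)CC1`: 5000 nM
- compound 2 `Nc1cccc(Nc2c(C(=O)NCc3ccc(F)cc3)nc(Br)c3cccnc23)c1`: 8000 nM

In this assay, compound 2 gives 8000 nM, a number within the usual scatter of compound 1 at 5000 nM. The two therefore cannot be ranked, even though they carry different groups on the shared core.

Compound 3 `O=C(NCc1ccc(F)cc1)c1nc(Br)c2cccnc2c1NCc1ccc(F)cc1` departs from compound 2 in one place: 4-fluorobenzyl in place of 3-aminophenyl on a nitrogen on an aromatic ring. In words, this puts 4-fluorobenzyl in place of 3-aminophenyl on a nitrogen on an aromatic ring.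

Going by the values given here, no measured pair of compounds shows what a swap of this kind does, so the expectation rests on little. No shift beyond the scatter is expected in this assay, and neither direction is favoured. The expected change is a 1.3-fold lower number from compound 2 to compound 3 (0.12 log units; within the scatter). The estimated value for compound 3 is 6000 nM, with an expected range from 2000 nM to 18000 nM.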

Compound 3, half-maximal inhibitory concentration: > 20000 nM
Compound 3 ended at the assay's limit (the forecaster's own chance of this, stated with the estimate: 20%); middle value at least 3.3-fold (0.52 log units) away from the limit.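

In this assay, going by these compounds alone, putting 4-fluorobenzyl in place of 3-aminophenyl on this nitrogen gives an at least 2.5-fold higher number from compound 2 to compound 3 (0.39 log units; beyond the scatter) and is the first step here that lies beyond the scatter. It shows that the group on this nitrogen can move the result on its own, and this swap moves it towards weaker inhibition. The value of compound 3 is a limit and not a number, so the step has a known minimum but no known full size: the limit of > 20000 nM in this assay, at which 1 of the 3 values shown sits.

The swap changes several things at once, since the amino group on the ring leaves while a fluorine and one more carbon enter, and the step cannot separate these parts. As far as these compounds go, whether a plain benzyl or a 3-aminobenzyl on this nitrogen would behave like compound 2 or like compound 3 stays open.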